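The source may report more compounds than this note shows. Statements on the series, on what has been measured and on what is new or still open speak of the compounds shown alone.

Measured compounds:
compound 1 `COc1cc(/C=C/C(=O)/C=C(/C=C/c2ccc(OC(C)=O)c(OC)c2)NC2CCCCC2)ccc1OC(C)=O` — 9700 nM in a functional assay on Caco-2 cells (Homo sapiens) for inhibition, read by MTT assay, with a stated time of 72 h; a lower number here means a stronger inhibitor, a higher number a weaker inhibitor
compound 2 `COc1cc(/C=C/C(=O)/C=C(/C=C/c2ccc(OC(C)=O)c(OC)c2)NCC(C)C)ccc1OC(C)=O` — > 25000 nM
compound 3 `COc1cc(/C=C/C(=O)/C=C(/C=C/c2ccc(O)c(OC)c2)NC2CCCCC2)ccc1O` — > 25000 nM

In this assay compound 1 gives 9700 nM. For compound 2 the value is a limit of the assay, > 25000 nM. For compound 3 the value is also a limit of the assay, > 25000 nM. The change isobutyl in place of cyclohexyl on an amine nitrogen gives an at least 2.5-fold higher number from compound 1 to compound 2 (0.41 log units; beyond the scatter). The difference between the core of compound 1 and the core of compound 3 is not broken down here. Compound 4 `COc1cc(/C=C/C(=O)/C=C(/C=C/c2ccc(O)c(OC)c2)NCC(C)C)ccc1O` has not been measured in this assay; it differs from compound 3 by isobutyl in place of cyclohexyl on an amine nitrogen, the same change at the same place as before. Two of the three values sit at the limit of > 25000 nM in this assay, at which 2 of the 3 values shown sit. Compound 4 is expected to remain at that limit, an estimated step that the limit leaves unreadable from compound 3 to compound 4, because an at least 2.5-fold higher number from compound 1 to compound 2 (0.41 log units; beyond the scatter) weakened inhibition when applied to compound 1. The estimate for compound 4 is 45000 nM, expected between 25000 nM and 120000 nM.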

Compound 4, half-maximal inhibitory concentration: > 25000 nM
Compound 4 ended at the assay's limit; the forecaster's own chance of this, stated with the estimate: 85%; the middle value does not contradict the limit.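

Compound 3 gives > 25000 nM, a limit of the assay. Compound 4 gives > 25000 nM, also a limit, so no step can be read between these two compounds. The compounds shown leave open whether isobutyl in place of cyclohexyl on an amine nitrogen changes inhibition on the core of compound 3.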